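Does a Double Bond in the Chain Change Hemolysis?

This account rests on a few compounds, and the source may have more. Where it says the series, first, only, none or still open, it means among the compounds named here.

Compound 1 `CCCCCCCCCCCCCC(=O)NCc1ccc(C(=O)N[C@H](C(=O)O)[C@@H](C)CC)cc1`: 66 ug/mL
Compound 2 `CCCCCCCCCC(=O)NCc1ccc(C(=O)N[C@H](C(=O)O)[C@@H](C)CC)cc1`: > 1000 ug/mL, a limit of the assay and not a number.
Compound 3 `CCCCCCCCCCCCCCCC(=O)NCc1ccc(C(=O)N[C@H](C(=O)O)[C@@H](C)CC)cc1`: 50 ug/mL

In a toxicity assay on cells (Erythrocyte, Homo sapiens) for cytotoxicity, read by hemolysis (on this read-out higher numbers stand for an effect only at larger amounts of compound and lower numbers for an effect already at smaller amounts), compound 3 gives 50 ug/mL, within the scatter of compound 1 at 66 ug/mL. Compound 4 `CCCCCC/C=C\CCCCCCCC(=O)NCc1ccc(C(=O)N[C@H](C(=O)O)[C@@H](C)CC)cc1` is not yet measured. It differs from compound 3 as follows: a group of 8 heavy atoms (8 carbon; no ring) in place of a group of 8 heavy atoms (8 carbon; no ring), on a saturated chain carbon, seven bonds along the chain from a carbonyl carbon. Octyl leaves, and a group of equal size with a double bond enters. Among the measured compounds shown here, two measured steps bear on this. One is large: an at least 20-fold lower number from compound 2 to compound 3 (1.30 log units; beyond the scatter). The other stays within the scatter: a 1.3-fold lower number from compound 1 to compound 3 (0.12 log units; within the scatter). Neither tests a double bond, but compound 4 keeps the heavy-atom count of compound 3, so no step beyond the scatter is expected. The estimated step is a 1.4-fold higher number from compound 3 to compound 4 (0.15 log units; within the scatter). Compound 4 is expected at 70 ug/mL, with an estimated range of 25 ug/mL to 200 ug/mL.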

Compound 4, half-maximal effective concentration: 250 ug/mL
For compound 4 the middle estimate is 3.6-fold (0.55 log units) below the measured one, and the stated range ends below it.
By their numbers in this assay, from the lowest: compounds 3 and 1 (each within the scatter of the next); then compound 4. At a limit, above all of these: compound 2.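

At the same heavy-atom count, a double bond seven bonds along the chain from a carbonyl carbon still gives a 5.0-fold higher number from compound 3 to compound 4 (0.70 log units; beyond the scatter) in this assay, so chain size alone does not set the number here. Compound 4 also stands apart from both shorter chains, with a 3.8-fold higher number from compound 1 to compound 4 (0.58 log units; beyond the scatter) and an at least 4.0-fold lower number from compound 2 to compound 4 (0.60 log units; beyond the scatter). The value of compound 2 is a limit and not a number: the limit of > 1000 ug/mL in this assay, at which 1 of the 4 values shown sits.

Still open, on these data alone, is whether a longer chain carrying the same double bond would behave alike. So is what an amine at this place would give.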